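The compounds below may be only part of what the source reports. "The series", "measured", "known", "first", "only" and "open" are said of these compounds alone.

Series so far (a functional assay on HUVEC cells (Homo sapiens) for antiproliferative activity, read by MTT assay, with a stated time of 24 h; on this read-out lower numbers stand for stronger inhibition and higher numbers for weaker inhibition)
compound 1 (`C=CCc1cc(-c2cccc(C(F)(F)F)c2)ccc1O`): 76000 nM
compound 2 (`C=CCc1cc(-c2ccc(NC(C)=O)cc2)ccc1OC`): > 100000 nM
compound 3 (`C=CCc1cc(C=O)c(OCC)c(-c2ccc(OCC)c(CC=C)c2)c1`): 37900 nM

Among the measured compounds shown here, compound 1 at 76000 nM and compound 3 at 37900 nM lie within the scatter of each other, and they are the only two numbers in hand. For compound 2 the entry > 100000 nM is a limit and not a number.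

Still unmeasured is compound 4 (`C=CCc1cc(-c2cccc(SC)c2)ccc1O`), which has methylsulfanyl in place of trifluoromethyl on an aromatic carbon, meta to a large group (methylsulfanyl in place of trifluoromethyl on an aromatic carbon). For the measured compounds named here, no measured pair isolates this exchange, so no step beyond the scatter is expected in this assay, and neither direction is favoured. The estimate is anchored on compound 1 at 76000 nM as the closest measured structure. The estimated step of a 1.3-fold lower number from compound 1 to compound 4 (0.10 log units; within the scatter) fits that expectation. For compound 4 the expected value is 60000 nM (estimated range 25000 nM to 100000 nM).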

Compound 4, half-maximal inhibitory concentration: > 100000 nM
Compound 4: a limit, no number (the forecaster's own chance of this, stated with the estimate: 20%); middle value at least 1.6-fold (0.22 log units) from the limit.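

The exchange of methylsulfanyl for trifluoromethyl on an aromatic carbon, meta to a large group, now has a pair differing in one place in this assay, and it reads as an at least 1.3-fold higher number from compound 1 to compound 4 (0.11 log units; that floor lies within the scatter). Compound 4 gives > 100000 nM, which is a limit and not a number. The step therefore has only a floor, and neither its size nor whether it exceeds the scatter can be read; the result sits at the edge of what this read-out resolves: the limit of > 100000 nM in this assay, at which 2 of the 4 values shown sit.

Open, as far as these compounds go, is how an amine or a carboxylic acid on this aromatic carbon would read in this assay. Also open, from the compounds shown here alone, is whether any exchange at this place gives a step beyond the scatter, and a measured number for a methylsulfanyl analogue would be needed to size this one.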